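The source may report more compounds than this note shows. Statements on the series, on what has been measured and on what is new or still open speak of the compounds shown alone.

Measured so far in a functional assay on NCI-H226 cells (Homo sapiens) for inhibition, read by MTT assay, with a stated time of 48 h, tested at 10 uM; on this read-out lower numbers stand for less inhibition and higher numbers for more inhibition at the one concentration tested (going by the name of the read-out):
compound 1 `COc1cc(NC(=O)Nc2cc(Nc3cccc(C(C)(C)C)c3)ncn2)cc(OC)c1`: 40%
compound 2 `COc1cc(Nc2cc(NC(=O)Nc3c(Cl)cccc3Cl)ncn2)cc(OC)c1`: 60%

Compound 1 gives the lower of the two numbers in this assay; compound 2 lies higher by a gap beyond the scatter. Compound 3 `COc1cc(NC(=O)Nc2cc(Nc3ccc(OC)c(C)c3)ncn2)cc(OC)c1` is not yet measured. The change from compound 1 is 4-methoxy-3-methylphenyl in place of 3-(tert-butyl)phenyl on a nitrogen on an aromatic ring. Among the measured compounds shown here, no step between measured compounds bears on this change, so its direction is unknown; the expected step is small, a number 2 percentage points higher from compound 1 to compound 3 (within the scatter), not clearly beyond the scatter. Compound 3 is estimated at 42%, with a range from 15% to 70%.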

Compound 3, a percentage reported as inhibition, at one concentration (the size of the read-out at that concentration, not a potency): 39.7%
For compound 3 the middle estimate is 2.3 percentage points above the measured one, within the range that was stated.
By their numbers in this assay, from the lowest: compounds 3 and 1 (each within the scatter of the next); then compound 2.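

In this assay, 4-methoxy-3-methylphenyl in place of 3-(tert-butyl)phenyl on the nitrogen gives a number 0.3 percentage points lower from compound 1 to compound 3 (within the scatter) and so leaves the read-out unmoved beyond the scatter. This position therefore accepts the exchange of a carbon-only tert-butyl substituent for methoxy and methyl substituents, including the added hydrogen-bond acceptor, without a clear change in the number. No available evidence bears on this result.

Still open, going by these compounds, is whether a piperazine or a carboxylic acid on this phenyl ring would shift the number beyond the scatter. Also open, on these data alone, is whether an unsubstituted phenyl at this position would do so.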